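The source may hold more compounds than are shown below. What is called first, only, known or untested is meant among the compounds shown, and "the series" means these compounds.

Values measured so far in a functional assay on P388 cells (Mus musculus) for cytotoxicity; a higher number here means a weaker inhibitor, a lower number a stronger inhibitor:
Compound 1 `Nc1ncnc2c1ncn2C1CC(COS(N)(=O)=O)C(O)C1O` gives 0.125 ug/mL
Compound 2 `CNc1ncnc2c1ncn2C1CC(COS(N)(=O)=O)C(O)C1O` gives 4 ug/mL
Compound 3 `CN(C)c1ncnc2c1ncn2C1CC(COS(N)(=O)=O)C(O)C1O` gives 74 ug/mL

Compound 3 has the highest number of the three, making it the weakest inhibitor here. Compound 4 `CSc1ncnc2c1ncn2C1CC(COS(N)(=O)=O)C(O)C1O` differs from it as follows: methylsulfanyl in place of dimethylamino on an aromatic carbon with methylsulfanyl in place of dimethylamino on an aromatic carbon. The closest evidence is the pair of methyl steps on the nitrogen, a 32-fold higher number from compound 1 to compound 2 (1.51 log units; beyond the scatter) and a 19-fold higher number from compound 2 to compound 3 (1.27 log units; beyond the scatter) in turn, which add up to a 590-fold higher number from compound 1 to compound 3 (2.77 log units; beyond the scatter) across these three compounds. Among the measured compounds shown here, no measured step swaps nitrogen for sulfur, so this guide is rough. The entering group has fewer heavy atoms, so a modest move in this assay toward a lower number is expected, with the estimated step being a 3.7-fold lower number from compound 3 to compound 4 (0.57 log units; beyond the scatter) in size. Compound 4 is estimated at 20 ug/mL with an expected range from 4 ug/mL to 100 ug/mL in this assay.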

Compound 4, half-maximal inhibitory concentration: 50 ug/mL
For compound 4 the middle estimate is 2.5-fold (0.40 log units) below the measured one; the measured number falls inside the stated range.
By their numbers in this assay, from the lowest: compound 1; then compound 2; then compounds 4 and 3 (each within the scatter of the next).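

In this assay, methylsulfanyl in place of dimethylamino gives a 1.5-fold lower number from compound 3 to compound 4 (0.17 log units; within the scatter), so these two groups cannot be told apart at this aromatic carbon. Methylsulfanyl compares far less well with methylamino and amino, giving a 13-fold higher number from compound 2 to compound 4 (1.10 log units; beyond the scatter) and a 400-fold higher number from compound 1 to compound 4 (2.60 log units; beyond the scatter), so changing nitrogen to sulfur does not recover the strength of compound 1. Nothing available explains these steps. The compounds shown leave open how a hydroxyl group or a chlorine atom would behave on this carbon, and whether a longer sulfur chain such as ethylsulfanyl would match methylsulfanyl.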